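Replacing benzyloxy on the carbonyl carbon: compound 3 to compound 4

A few compounds are considered here, and "the series" means these few. Any claim that something is new, unique, unknown or untested is made for them only; others in the source may bear on it.

In a functional assay on the whole organism for inhibition, with Mus musculus as the target (on this read-out lower numbers stand for an effect already at smaller amounts and higher numbers for an effect only at larger amounts of compound), compound 2 `CCOC(=O)Nc1cccc2c1CN(C)CC2c1ccccc1` gives about 4 mg/kg and compound 3 `CN1Cc2c(NC(=O)OCc3ccccc3)cccc2C(c2ccccc2)C1` gives 16 mg/kg, the higher of the two numbers. Compound 1 `CCCNC(=O)Nc1cccc2c1CN(C)CC2c1ccccc1` sits at a limit, > 80 mg/kg, and has no exact number.

Compound 4 `CCNCCC(=O)Nc1cccc2c1CN(C)CC2c1ccccc1` differs from compound 3 by 2-(ethylamino)ethyl in place of benzyloxy on a carbonyl carbon. All measured steps fall at this same carbonyl carbon. Among the two oxygen-linked groups, the change is modest: a 4.0-fold higher number from compound 2 to compound 3 (0.60 log units; beyond the scatter). Propylamino is clearly less favourable than either, as seen in an at least 20-fold lower number from compound 1 to compound 2 (1.30 log units; beyond the scatter), which is large, and an at least 5.0-fold lower number from compound 1 to compound 3 (0.69 log units; beyond the scatter), which is at least modest. Within the data shown here, no measured compound carries a group like 2-(ethylamino)ethyl, so the evidence is indirect. Its nitrogen-containing chain resembles compound 1 more than compound 2 or compound 3, and a modest rise in the number is expected, with a limit reading possible. The expected size is a 2.2-fold higher number from compound 3 to compound 4 (0.34 log units; beyond the scatter). For compound 4 the estimated value is 35 mg/kg, within an expected range of 10 mg/kg to 120 mg/kg.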

Compound 4, dose for half-maximal effect: > 160 mg/kg
Compound 4: only a limit was reported; the forecaster's own chance of this, stated with the estimate: 35%; at least 4.5-fold (0.66 log units) between middle value and limit.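

Compound 4 is read only as a limit: the limit of > 160 mg/kg in this assay, at which 1 of the 4 values shown sits. Even so, the steps are clear: an at least 10-fold higher number from compound 3 to compound 4 (1.00 log units; beyond the scatter), and an at least 40-fold higher number from compound 2 to compound 4 (1.60 log units; beyond the scatter). Loss at this carbonyl carbon is therefore not confined to propylamino: 2-(ethylamino)ethyl, which joins the carbonyl through carbon rather than through oxygen or nitrogen, also falls short of both oxygen-linked groups in this assay, so that among the four compounds only ethoxy and benzyloxy give exact numbers. Compound 1 and compound 4 both stand at limits, and the step between them cannot be read.

Whether the chain nitrogen or the carbon link accounts for the loss stays open, and a plain butyl chain on the carbonyl carbon would separate the two. From the compounds shown here alone, it is also open whether an oxygen-linked group carrying an amine, such as 2-(ethylamino)ethoxy, would keep the numbers of compound 2 and compound 3.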